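The compounds below may be only part of what the source reports. "The series", "measured", "known", "first", "only" and "open" are said of these compounds alone.

Notes on the series, all read in a functional assay on MCF7 cells (Homo sapiens) for antiproliferative activity, read by MTT assay, with a stated time of 72 h; on this read-out lower numbers stand for stronger inhibition and higher numbers for weaker inhibition. Compound 1 `NC(=S)N1N=C(c2ccc(N3CCCCC3)cc2)CC1c1ccc(Cl)cc1` gives 22300 nM. Compound 2 `Fc1ccc(-c2csc(N3N=C(c4ccc(N5CCCCC5)cc4)CC3c3ccc(Cl)cc3)n2)cc1` gives 23100 nM, and the two stand level: a 1.0-fold higher number from compound 1 to compound 2 (0.02 log units; within the scatter). Compound 3 `Clc1ccc(-c2csc(N3N=C(c4ccc(N5CCCCC5)cc4)CC3c3ccc(Cl)cc3)n2)cc1` is reported only as a limit, > 100000 nM, and not as a number.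

The next step leads from compound 2 to compound 4 `N#Cc1ccc(-c2csc(N3N=C(c4ccc(N5CCCCC5)cc4)CC3c3ccc(Cl)cc3)n2)cc1`: cyano in place of fluoro on an aromatic carbon. In words, this is cyano in place of fluoro on an aromatic carbon, para to a large group, or 4-fluorophenyl to 4-cyanophenyl.

Among the measured compounds shown here, only one measured step changes this same place, chloro in place of fluoro: an at least 4.3-fold higher number from compound 2 to compound 3 (0.63 log units; beyond the scatter). The comparison with the thiocarbonyl-bearing parent reads similarly: an at least 4.4-fold higher number from compound 1 to compound 3 (0.65 log units; beyond the scatter). Both sizes are lower bounds, and they rest on a single compound, so they suggest a direction more than a size. A small move toward a higher number is therefore expected, possibly one that stays within the scatter.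

The expected step is a 1.5-fold higher number from compound 2 to compound 4 (0.18 log units; within the scatter). For compound 4 the estimate is 35000 nM, with an expected range of 9000 nM to 100000 nM.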

Compound 4, half-maximal inhibitory concentration: 9760 nM
Estimate against measurement, compound 4: 3.6-fold (0.55 log units) above, and the stated range covers the measured number.
By their numbers in this assay, from the lowest: compound 4; then compounds 1 and 2 (each within the scatter of the next). At a limit, above all of these: compound 3.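

In this assay, among the compounds shown here, the group on this aromatic carbon now moves the number in both directions: a 2.4-fold lower number from compound 2 to compound 4 (0.37 log units; beyond the scatter), whereas the only earlier change here, chloro in place of fluoro, went the other way. The widest gap at this place is an at least 10-fold lower number from compound 3 to compound 4 (1.01 log units; beyond the scatter), so the three groups on this carbon span a clear range even though the core stays the same. Compound 3 is reported only as a limit, so that gap is a lower bound: the limit of > 100000 nM in this assay, at which 1 of the 4 values shown sits.

With one compound per group, nothing here tells which feature of cyano goes with the lower number or why chloro departs so far from fluoro. A methoxy, a trifluoromethyl or a carboxylic acid on this same carbon would show whether compound 3 or compound 4 is the exception.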